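Replacing the Outer Aryl Ring in a Sulfonamide Agonist Series

A few compounds are considered here, and "the series" means these few. Any claim that something is new, unique, unknown or untested is made for them only; others in the source may bear on it.

Compound 1, `C[C@@H]1CN(c2cc(NS(=O)(=O)c3ccc(-c4ccccn4)s3)ccc2C#N)C[C@H](C)N1`, gives 0.9 in a functional assay for agonist activity at growth hormone secretagogue receptor type 1 (Homo sapiens), read by FLIPR; on this read-out higher numbers stand for larger maximal responses and lower numbers for smaller maximal responses.
Compound 2, `C[C@@H]1CN(c2ccc(F)c(NS(=O)(=O)c3ccc(-c4ccccn4)s3)c2)C[C@H](C)N1`, gives 0.8.
Compound 3, `COc1ccc(N2C[C@@H](C)N[C@@H](C)C2)cc1NS(=O)(=O)c1ccc(-c2cc(Cl)ccc2F)cc1`, gives 1.

All three measured compounds share a sulfonamide-linked core, and each reaches close to the full response of the reference agonist in this assay. Compound 3 gives the highest number of the three, but compound 1 sits within the scatter of it, so the two cannot be told apart; only compound 2 lies beyond the scatter below compound 3. Whatever the outer aromatic ring on the sulfonyl side looks like in these three, the maximal response stays high.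

Compound 4, `COc1ccc(N2C[C@@H](C)N[C@@H](C)C2)cc1NS(=O)(=O)c1ccc(-c2cccs2)cc1`, keeps everything in compound 3 except that outer ring. thiophen-2-yl in place of 5-chloro-2-fluorophenyl on an aromatic carbon The group that enters is smaller and carries a hetero atom, yet the three measured compounds give no sign that this region governs the size of the response. The step a number 0.10 lower from compound 3 to compound 4 (within the scatter) is therefore expected to stay within the usual scatter, with no clear direction. Compound 4 is estimated to give 0.9 in this assay, most likely between 0.7 and 1.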

Compound 4, intrinsic activity: the largest response reached, as a fraction of the reference agonist's: 1
For compound 4 the middle estimate is 0.10 below the measured one, within the range that was stated.
By their numbers in this assay, from the lowest: compounds 2, 1, 3 and 4 (each within the scatter of the next, the first and the last beyond it).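

Among the compounds shown here, compounds 3 and 4 are the first pair here that differ in one place, so this outer ring can now be judged on its own rather than inferred from compounds that differ in several places. In this assay, putting thiophen-2-yl in place of 5-chloro-2-fluorophenyl, on an aromatic carbon para to a large group, gives no change at the digits printed from compound 3 to compound 4 (within the scatter). The maximal response therefore holds through a substantial change: the outer ring goes from six-membered to five-membered, from 8 heavy atoms to 5, loses its chlorine and fluorine, and gains a sulfur and a hydrogen-bond acceptor, though nothing available explains why the response holds.

For the compounds shown here, only two aromatic rings can be compared at this position, so it remains open whether a ring-free group, such as a carboxylic acid, an amine or a longer alkyl chain, would keep the response on the core of compound 3. This read-out also reports only the largest response reached, so it leaves open whether the swap changes the concentration needed to reach that response.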